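This account rests on a few compounds, and the source may have more. Where it says the series, first, only, none or still open, it means among the compounds named here.

Of the compounds shown here, three sharing one core have been measured in a functional assay on UO-31 cells (Homo sapiens) for antiproliferative activity, read by sulforhodamine B assay, with a stated time of 72 h; a higher number here means a weaker inhibitor, a lower number a stronger inhibitor. Compound 1 (`Fc1ccc(Nc2nncc3ccccc23)cc1`) gives 4.7 nM, compound 2 (`O=S(=O)(Nc1ccccn1)c1ccc(Nc2nncc3ccccc23)cc1`) gives 44 nM, and compound 3 (`NS(=O)(=O)c1ccc(Nc2nncc3ccccc23)cc1`) gives 23 nM. Compound 3 therefore stands within the scatter of compound 2 and clearly apart from compound 1. Compound 4 (`N#Cc1ccc(Nc2nncc3ccccc23)cc1`) differs from compound 3 by cyano in place of sulfamoyl on an aromatic carbon.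

Going by the values given here, two measured steps bear on this change. Sulfamoyl in place of fluoro gave a 4.9-fold higher number from compound 1 to compound 3 (0.69 log units; beyond the scatter), a modest step beyond the scatter. Hydrogen in place of pyridin-2-yl on a sulfonamide nitrogen gave a 1.9-fold lower number from compound 2 to compound 3 (0.28 log units; within the scatter), which stays within the scatter. Among the compounds with values here, no measured compound carries cyano, so the size of the step remains uncertain. Compound 4 also loses the sulfamoyl group, and a partial return toward compound 1 at 4.7 nM is expected. The expected change is a 2.3-fold lower number from compound 3 to compound 4 (0.36 log units; beyond the scatter), a modest step. Compound 4 is estimated at 10 nM, with an expected range of 3.5 nM to 28 nM.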

Compound 4, half-maximal inhibitory concentration: 2 nM
Estimate against measurement, compound 4: 5.0-fold (0.70 log units) above; measured number outside the range, below it.
By their numbers in this assay, from the lowest: compound 4; then compound 1; then compounds 3 and 2 (each within the scatter of the next).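

Placed on the aromatic carbon para to a large group, cyano in place of sulfamoyl gives a 12-fold lower number from compound 3 to compound 4 (1.06 log units; beyond the scatter) in this assay, a large step that is bigger than the earlier move from fluoro to sulfamoyl and runs the opposite way. Cyano in place of fluoro also gives a 2.4-fold lower number from compound 1 to compound 4 (0.37 log units; beyond the scatter) beyond the scatter, so fluoro no longer marks the lower end at this position, as it did among the earlier compounds. Nothing shown here explains either step.

The compounds shown leave open whether a lower number at this position is particular to cyano or would also follow from a chloro, a methoxy, an amine or a carboxylic acid in the same place. They also leave open whether cyano would hold this advantage on other cell lines.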